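The source may report more compounds than this note shows. Statements on the series, on what has been measured and on what is new or still open speak of the compounds shown alone.

Compound 1, `O=S(=O)(Oc1ccc(Cl)cc1)C1CC2OC1C(c1ccc(/C=C/c3cc(O)cc(O)c3)cc1)=C2c1ccc(O)cc1`: 17900 nM
Compound 2, `O=S(=O)(Oc1ccccc1Cl)C1CC2OC1C(c1ccc(/C=C/c3cc(O)cc(O)c3)cc1)=C2c1ccc(O)cc1`: 40400 nM
Compound 3, `Cc1ccc(OS(=O)(=O)C2CC3OC2C(c2ccc(/C=C/c4cc(O)cc(O)c4)cc2)=C3c2ccc(O)cc2)cc1`: 9200 nM

These three compounds share one core and differ only in the aryl group on the sulfonyl oxygen, and all were tested in a functional assay on MCF7 cells (Homo sapiens) for antiproliferative activity, read by MTT assay, with a stated time of 72 h; on this read-out lower numbers stand for stronger inhibition and higher numbers for weaker inhibition. Compound 2 gives the highest number and is the weakest of the three, since a 2.3-fold higher number from compound 1 to compound 2 (0.35 log units; beyond the scatter) and a 4.4-fold lower number from compound 2 to compound 3 (0.64 log units; beyond the scatter) both lie beyond the scatter. Compound 4, `O=S(=O)(Oc1cccc2ccccc12)C1CC2OC1C(c1ccc(/C=C/c3cc(O)cc(O)c3)cc1)=C2c1ccc(O)cc1`, is not yet measured. Its change from compound 2 is naphthalen-1-yl in place of 2-chlorophenyl on an oxygen. Among the measured compounds shown here, the two steps that alter the same aryl group, a 2.3-fold higher number from compound 1 to compound 2 (0.35 log units; beyond the scatter) and a 4.4-fold lower number from compound 2 to compound 3 (0.64 log units; beyond the scatter), both show that moving away from 2-chlorophenyl lowers the number, so a modest lowering is expected for compound 4 too, though no measured compound carries a second aromatic ring there. Compound 4 is therefore expected to give 18000 nM in this assay, within 6000 nM to 50000 nM. The expected step is thus a 2.2-fold lower number from compound 2 to compound 4 (0.35 log units; beyond the scatter).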

Compound 4, half-maximal inhibitory concentration: 11000 nM
Estimate against measurement, compound 4: 1.6-fold (0.21 log units) above, within the range that was stated.
By their numbers in this assay, from the lowest: compounds 3, 4 and 1 (each within the scatter of the next); then compound 2.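

In this assay this position accepts naphthalen-1-yl, with its 2 six-membered aromatic rings of carbon only, as the step of a 3.7-fold lower number from compound 2 to compound 4 (0.56 log units; beyond the scatter) shows. Among the compounds shown here, that group cannot be told apart from the groups with one ring, as the steps of a 1.2-fold higher number from compound 3 to compound 4 (0.08 log units; within the scatter) and a 1.6-fold lower number from compound 1 to compound 4 (0.21 log units; within the scatter) show, so 2-chlorophenyl remains the only group here that stands apart. No measured evidence explains these differences. Still open, from the compounds shown here alone, is how an amine or a carboxylic acid on this aryl group, or a simple alkyl chain in its place, would read.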